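The compounds below may be only part of what the source reports. "The series", "measured", "known", "first", "only" and "open" are said of these compounds alone.

Working notes on the series. In an ADME assay on microsomes from liver (Rattus norvegicus, strain Sprague-Dawley) for metabolic stability, read by LC-MS, using NADPH, with a stated time of 45 min, tested at 3 uM (on this read-out higher numbers stand for a longer-lived compound and lower numbers for a shorter-lived compound), compound 1 (`C1CCC(C(CC2CCCCN2)C2CCC2)CC1`) gives 0.167 h, compound 2 (`C1CCC(CC(C2CCCC2)C2CCC2)NC1`) gives 0.117 h, and compound 3 (`C1CCC(CC(C2CCCC2)C2CCCC2)NC1`) gives 0.233 h. Compound 1 therefore stands among the three numbers, within the scatter of both the others.

The next compound to be read is compound 4 (`c1ccc(C(CC2CCCCN2)C2CCCCC2)cc1`), which has no value yet. Its difference from compound 1 is phenyl in place of cyclobutyl on a saturated chain carbon bound to a saturated chain carbon and a saturated ring carbon. In words, this is phenyl in place of cyclobutyl on a saturated chain carbon bound to a saturated chain carbon and a saturated ring carbon.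

Going by the values given here, two measured steps bear on this change, as both exchange one saturated ring for another at that same kind of carbon. The first is a 1.4-fold lower number from compound 1 to compound 2 (0.15 log units; within the scatter). The second is a 2.0-fold higher number from compound 2 to compound 3 (0.30 log units; within the scatter). Among the compounds with values here, neither step brings in an aromatic ring, so the data offer no direct precedent for phenyl and no direction for the change. With only these two steps as a guide, no change beyond the scatter is expected in this assay. The estimated step is a 1.0-fold higher number from compound 1 to compound 4 (0.01 log units; within the scatter). Compound 4 is expected at 0.17 h, with an estimated range from 0.08 h to 0.35 h.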

Compound 4, half-life: 0.0667 h
Estimate against measurement, compound 4: 2.5-fold (0.41 log units) above, and the stated range ends above it.
By their numbers in this assay, from the lowest: compounds 4, 2, 1 and 3 (each within the scatter of the next, the first and the last beyond it).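

In this assay, going by these compounds alone, the change of cyclobutyl to phenyl, on a saturated chain carbon bound to a saturated chain carbon and a saturated ring carbon, gives a 2.5-fold lower number from compound 1 to compound 4 (0.40 log units; beyond the scatter) and is the first step at this kind of carbon to lie beyond the scatter, though only modestly. Within the data shown here, the exchanges of one saturated ring for another, a 1.4-fold lower number from compound 1 to compound 2 (0.15 log units; within the scatter) and a 2.0-fold higher number from compound 2 to compound 3 (0.30 log units; within the scatter), both stayed within the scatter, so in these compounds this kind of carbon does not tolerate every ring exchange equally, and the half-life moves only with the one change that brings in an aromatic ring. No measurement at hand bears on what lies behind the shorter half-life of compound 4.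

This single step changes a four-membered non-aromatic ring into a six-membered aromatic ring, so the effect of ring size cannot be separated from that of aromatic character. From the compounds shown here alone, whether the step holds for other aromatic groups at this carbon remains open, and a pyridyl or fluorophenyl group there, or an open chain such as isopropyl, would test how far it extends.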